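A few compounds are considered here, and "the series" means these few. Any claim that something is new, unique, unknown or untested is made for them only; others in the source may bear on it.

For the measured compounds named here, in a physicochemical assay for acid dissociation, three compounds have numbers so far. Compound 3 `COc1cc(F)ccc1-c1ccnc2[nH]c(C3CCN(CC(=O)N(C)C)CC3)cc12` gives 8 and compound 2 `CC(C)n1cc(-c2ccnc3[nH]c(C4CCN(CC(=O)N5CCCC5)CC4)cc23)ccc1=O` gives 7.8, two values within the scatter of each other. Compound 1 `CNC(=O)CN1CCC(c2cc3c(-c4ccc(=O)n(C(C)C)c4)ccnc3[nH]2)CC1` gives 6.9, which is lower than compound 3 by more than the scatter.

Compound 4 `CC(C)n1nc(-c2ccnc3[nH]c(C4CCN(CC(=O)N(C)C)CC4)cc23)ccc1=O` keeps the rest of compound 3 and changes one group, on an aromatic carbon opposite the ring nitrogen: a group of 10 heavy atoms (7 carbon, 2 nitrogen, 1 oxygen; one six-membered aromatic ring with 2 hetero atoms) in place of a group of 9 heavy atoms (7 carbon, 1 oxygen, 1 fluorine; one six-membered aromatic ring of carbon only), on an aromatic carbon. Going by the values given here, the only measured step is modest (a number 0.90 log units higher from compound 1 to compound 2 (beyond the scatter)) and lies at a carbonyl carbon, away from this change, so no measured step isolates the group swap. The nearest hint comes from compound 2 and compound 3, which carry different groups on that aromatic carbon and on the carbonyl, yet stay within the scatter of each other.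

A small shift is therefore expected, with nothing beyond the scatter: the estimated step is a number 0.20 log units lower from compound 3 to compound 4 (within the scatter). For compound 4 the expected value is 7.8, with an estimated range from 7.3 to 8.2.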

Compound 4, acid dissociation constant: 7.6
Compound 4: middle estimate off by 0.20 log units, on the high side; the range from low to high includes it.
By their numbers in this assay, from the lowest: compound 1; then compounds 4, 2 and 3 (each within the scatter of the next, the first and the last beyond it).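

For the compounds shown here, this is the first step read at the aromatic carbon opposite the ring nitrogen. In this assay, replacing 4-fluoro-2-methoxyphenyl with the group of 10 heavy atoms, built on a six-membered aromatic ring with 2 hetero atoms, gives a number 0.40 log units lower from compound 3 to compound 4 (beyond the scatter). The group on this carbon can therefore shift the number beyond the scatter, though only modestly in this one case, and nothing available accounts for the shift.

A single swap cannot show how other groups at this carbon would read, such as an unsubstituted phenyl ring, a methyl group or a primary amine. It also leaves open whether the same swap would give a similar step with pyrrolidin-1-yl in place of the dimethylamino group on the carbonyl.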